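Methyl on an aromatic carbon in a level series

The source may report more compounds than this note shows. Statements on the series, on what has been measured and on what is new or still open speak of the compounds shown alone.

In a functional assay on MCF7 cells (Homo sapiens) for antiproliferative activity, read by MTT assay (a lower number here means a stronger inhibitor, a higher number a weaker inhibitor), compound 1 (`CC/C=C\C/C=C\C/C=C\CCCCCCCc1cc(=O)c2c(O)cc(O)cc2o1`) gives 17500 nM. Compound 2 (`CC/C=C\C/C=C\C/C=C\CCCCCCCc1cc(=O)c2c(O)cc(OCOC)cc2o1`) gives 17500 nM, and compound 3 (`CCCC/C=C\CCCCCCCCCc1cc(=O)c2c(O)cc(O)cc2o1`) gives 17500 nM. Compound 1 therefore stands level with both, and the three measurements show no spread in activity.

Compound 4 (`CC/C=C\C/C=C\C/C=C\CCCCCCCc1cc(=O)c2c(O)cc(O)c(C)c2o1`) is still unmeasured and differs from compound 1 at one place: methyl in place of hydrogen on an aromatic carbon. In words, this is methyl in place of hydrogen on an aromatic carbon, para to a hydroxy group.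

Going by the values given here, two measured steps bear on this change, both only indirectly. Methoxymethyl in place of hydrogen on an oxygen on an aromatic ring gave no change at the digits printed from compound 1 to compound 2 (within the scatter). The change in the chain gave no change at the digits printed from compound 1 to compound 3 (within the scatter). Among the compounds with values here, neither step places a methyl on an aromatic carbon, so the series holds no direct precedent for this substitution. The two steps show only that the activity stayed level through one change on the core and one on the chain.

No step beyond the scatter is therefore expected in this assay, and no direction is favoured. The estimated step is a 1.1-fold lower number from compound 1 to compound 4 (0.04 log units; within the scatter). For compound 4 the estimated value is 16000 nM, with an expected range of 7000 nM to 35000 nM.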

Compound 4, half-maximal inhibitory concentration: 17500 nM
Compound 4: middle estimate off by 1.1-fold (0.04 log units), on the low side; the measured number falls inside the stated range.
By their numbers in this assay, from the lowest: compounds 1, 2, 3 and 4 (each within the scatter of the next).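

In this assay, methyl in place of hydrogen on an aromatic carbon, ortho to a hydroxy group and para to a hydroxy group, gives no change at the digits printed from compound 1 to compound 4 (within the scatter). Going by these compounds alone, this is the first direct reading at this carbon of the shared core: the earlier steps touched an oxygen on the ring and the chain, and this one shows that a ring carbon of compound 1 also takes a methyl with no step beyond the scatter. No measurement shown accounts for this flat result.

Going by these compounds, whether this carbon accepts more than a single methyl stays open, since an ethyl group, a chlorine atom, an amine or a carboxylic acid at the same place could read differently from the methyl of compound 4. Within the data shown here, with no step beyond the scatter, it also stays open which parts of the shared core and chain the activity depends on, and a much shorter chain or a compound lacking the hydroxy group para to this carbon would test that.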